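Methyl for Chloro on the Fused Ring of Compound 3

The source may hold more compounds than are shown below. What is called first, only, known or untested is meant among the compounds shown, and "the series" means these compounds.

Measured so far in a functional assay on the whole organism (Hindlimb, strain albino) with Mus musculus as the target, in the maximal electroshock model, with a stated time of 0.5 h; on this read-out lower numbers stand for an effect already at smaller amounts and higher numbers for an effect only at larger amounts of compound:

Compound 1 `CC(=O)N1N=C(Nc2nc3ccc(C)cc3s2)CC1c1ccccc1`: 106 umol/kg
Compound 2 `COc1ccc(C2CC(Nc3nc4ccc(C)cc4s3)=NN2C(C)=O)cc1O`: 73.9 umol/kg
Compound 3 `CC(=O)N1N=C(Nc2nc3ccc(Cl)cc3s2)CC1OC1=CC=C1`: 212 umol/kg

Compound 3 carries the highest number of the three; the gap to compound 1 lies within the usual scatter, the gap to compound 2 beyond it.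

Compound 4 `CC(=O)N1N=C(Nc2nc3ccc(C)cc3s2)CC1OC1=CC=C1` differs from compound 3 by methyl in place of chloro on an aromatic carbon. Going by the values given here, the only measured step, a 1.4-fold lower number from compound 1 to compound 2 (0.16 log units; within the scatter), concerns a substituent on a saturated ring carbon and does not bear on this change. Among the compounds with values here, compounds 1 and 3 differ in two places, so no single step isolates the chloro-to-methyl exchange. In this assay the step from compound 3 to compound 4 is therefore expected to be a 1.3-fold lower number from compound 3 to compound 4 (0.12 log units; within the scatter), within the scatter. Compound 4 is estimated at 160 umol/kg, with a range from 75 umol/kg to 340 umol/kg.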

Compound 4, dose for half-maximal effect: 160 umol/kg
For compound 4 middle estimate and measured number coincide at the digits printed; the range from low to high includes it.
By their numbers in this assay, from the lowest: compounds 2, 1, 4 and 3 (each within the scatter of the next, the first and the last beyond it).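

In this assay, methyl and chloro on this aromatic carbon are not separated, with a 1.3-fold lower number from compound 3 to compound 4 (0.12 log units; within the scatter) as the whole effect of the exchange. Going by these compounds alone, on the saturated ring carbon, the group of 5 heavy atoms with its four-membered ring is not separated from phenyl, at a 1.5-fold higher number from compound 1 to compound 4 (0.18 log units; within the scatter), whereas replacing 3-hydroxy-4-methoxyphenyl with it gives a 2.2-fold higher number from compound 2 to compound 4 (0.34 log units; beyond the scatter), the only step here beyond the scatter. No evidence is available that accounts for these steps.

From the compounds shown here alone, whether methoxy, trifluoromethyl or an amine on the same aromatic carbon would depart from methyl and chloro remains open.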